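Replacing the indazolyl arm: expected gain in lipophilicity

The compounds below may be only part of what the source reports. "The series", "measured", "known", "first", "only" and "open" are said of these compounds alone.

Compound 3 `CNC(=O)c1cc(C(=O)NC2CC2)cn(Cc2cccc3cn[nH]c23)c1=O` holds the lowest of the three numbers in a physicochemical assay for lipophilicity, at pH 7.4 (a lower number here means a more polar compound, a higher number a more lipophilic compound), giving 2.2. For the measured compounds named here, compound 1 `CNC(=O)c1cc(C(=O)NC2CC2)cn(Cc2ccc(OC)cc2)c1=O` gives 3 and compound 2 `CNC(=O)c1cc(C(=O)NC2CC2)cn([C@H](C)c2ccccc2)c1=O` gives 3.4; the only single-point step joining measured compounds is a number 0.80 log units lower from compound 1 to compound 3 (beyond the scatter). Compound 4 `CNC(=O)c1cc(C(=O)NC2CC2)cn(Cc2ccccc2F)c1=O` differs from compound 3 as follows: 2-fluorophenyl in place of 1H-indazol-7-yl on a saturated chain carbon bound to an aromatic nitrogen. That step roughly reverses the earlier move, since 4-methoxyphenyl and 2-fluorophenyl both carry no hydrogen-bond donor, so a rise of similar size beyond the scatter is expected, a number 1.00 log units higher from compound 3 to compound 4 (beyond the scatter). For compound 4 in this assay the estimate is 3.2, with a range from 2.7 to 3.7.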

Compound 4, distribution coefficient: 3
Compound 4: middle estimate off by 0.20 log units, on the high side; measured number inside the range.
By their numbers in this assay, from the lowest: compound 3; then compounds 1 and 4 (each within the scatter of the next); then compound 2.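

In this assay 2-fluorophenyl in place of 1H-indazol-7-yl gives a number 0.80 log units higher from compound 3 to compound 4 (beyond the scatter) and so sets compound 3 apart from a second arm without the indazole. Between those two arms there is no change at the digits printed from compound 1 to compound 4 (within the scatter) and this assay does not separate 4-methoxyphenyl from 2-fluorophenyl at this position. On the aromatic nitrogen, 2-fluorobenzyl in place of 1-phenylethyl gives a number 0.40 log units lower from compound 2 to compound 4 (beyond the scatter) and the branched arm keeps the higher number of this pair.

Nothing shown explains these shifts. Where an arm bearing an amine or a carboxylic acid would fall remains open.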